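A methyl gives way to fluoro

This account rests on a few compounds, and the source may have more. Where it says the series, first, only, none or still open, it means among the compounds named here.

Of the compounds shown here, two have so far been measured in an ADME assay on L6 cells (Rattus norvegicus) for cytotoxicity, read by fluorescence and resazurin assay, with a stated time of 72 h; a higher number here means that more compound is tolerated, a lower number that less compound is tolerated. Compound 1 (`Fc1ccc(C(c2ccn(-c3ccc(Cl)cc3)c2)n2ccnc2)cc1`) gives 63100 nM, and compound 2 (`Cc1ccc(C(c2ccn(-c3ccc(F)cc3)c2)n2ccnc2)cc1`) gives 60700 nM. These two numbers lie within the scatter of each other, so compound 2 stands level with compound 1 and neither can be ranked ahead.

The next compound, compound 3 (`Fc1ccc(C(c2ccn(-c3ccc(F)cc3)c2)n2ccnc2)cc1`), departs from compound 2 in a single place: fluoro in place of methyl on an aromatic carbon. This puts fluoro in place of methyl on an aromatic carbon, para to a large group, turning 4-methylphenyl into 4-fluorophenyl. Going by the values given here, no measured pair shows a change in one place, so the data hold no direct step to lean on. Among the compounds with values here, the only guide is the level shared by the two measured compounds, and no step beyond the scatter is expected in this assay, in either direction. The estimated step of a 1.0-fold higher number from compound 2 to compound 3 (0.01 log units; within the scatter) is expected to stay within that scatter. For compound 3 the expected value is 62000 nM, with an estimated range from 32000 nM to 115000 nM.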

Compound 3, half-maximal cytotoxic concentration: 87100 nM
Beside the measured number, compound 3's estimate is 1.4-fold (0.15 log units) below it, and the stated range covers the measured number.
By their numbers in this assay, from the lowest: compounds 2, 1 and 3 (each within the scatter of the next).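

Going by these compounds alone, the first steps in one place show that, on the ring carrying the methyl of compound 2, fluoro in place of methyl on an aromatic carbon, para to a large group, gives a 1.4-fold higher number from compound 2 to compound 3 (0.16 log units; within the scatter) in this assay, so 4-methylphenyl and 4-fluorophenyl cannot be told apart here. A second change, with chloro giving way to fluoro, gives a 1.4-fold higher number from compound 1 to compound 3 (0.14 log units; within the scatter) and likewise cannot be told apart from no change at all, so neither swap moves the number in this assay beyond the scatter. Nothing on hand offers an explanation for these results.

All three compounds shown carry only methyl, fluoro or chloro at these two sites, so what an amine, a carboxylic acid or a longer chain on the same aromatic carbons would do in this assay remains open. Also open, as far as these compounds go, is whether any change to the shared core, rather than to these small groups, would shift the number away from the level these three compounds hold.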